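Series notes: aryl-substituent swap on the shared core

The source may report more compounds than this note shows. Statements on the series, on what has been measured and on what is new or still open speak of the compounds shown alone.

In a physicochemical assay for acid dissociation, compound 1 `COc1cccc(CNCCCNc2ccnc3cc(C4CCCCC4)ccc23)c1O` gives 9.47, and compound 2 `COc1ccc(F)cc1CNCCCNc1ccnc2cc(C3CCCCC3)ccc12` gives 9.47. The step of no change at the digits printed from compound 1 to compound 2 (within the scatter) changes only the group on the saturated chain carbon bound to the amine nitrogen. Compound 3 `Clc1ccc(Oc2ccc3c(NCCCNCc4ccco4)ccnc3c2)cc1` gives 9.28 in this assay; it differs from compound 2 in more than one place, so its value is only a point of comparison. Compound 2 stands level with compound 1 at the digits printed, the two together the highest of the three numbers, and compound 3 lies a small distance below, within the scatter.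

Compound 4 `COc1ccc(F)cc1CNCCCNc1ccnc2cc(CC(C)C)ccc12` has not been measured. It differs from compound 2 as follows: isobutyl in place of cyclohexyl on an aromatic carbon. Among the measured compounds shown here, no measured step in this assay touches the aromatic carbon of the shared core; the one step known, from compound 1 to compound 2, sits at the other end of the molecule and showed no change beyond the scatter. Across the three measured compounds the numbers in this assay stay within the scatter of one another despite changes at two separate positions. The step of no change at the digits printed from compound 2 to compound 4 (within the scatter) is therefore expected to be none beyond the scatter. Compound 4 is estimated at 9.47, within the range 9.17 to 9.77.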

Compound 4, acid dissociation constant: 9.47
The estimate for compound 4 equals the measured number at the digits printed, and the stated range covers the measured number.
By their numbers in this assay, from the lowest: compounds 3, 1, 2 and 4 (each within the scatter of the next).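

In this assay, among the compounds shown here, isobutyl in place of cyclohexyl on an aromatic carbon gives no change at the digits printed from compound 2 to compound 4 (within the scatter) and this is the first reading for a single change at this position of the shared core. The step takes out the six-membered non-aromatic ring and goes from 6 heavy atoms to 4, yet the read-out stays within the scatter, so between these two groups of carbon only, each with 0 hydrogen-bond donors and 0 hydrogen-bond acceptors, ring and size make no visible difference at this position. Nothing in hand accounts for this, and the result stands as an observation without an explanation.

Cyclohexyl and isobutyl are both groups of carbon only, so it remains open whether the number also holds with a group of another kind on this aromatic carbon, such as an amine, a carboxylic acid or a longer chain. Also open, going by these compounds, is whether the same swap gives the same reading when made on compound 1, which carries 2-hydroxy-3-methoxyphenyl in place of 5-fluoro-2-methoxyphenyl.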